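Chloro placement in an imidazolylpropyl diaryl ether series

The source may report more compounds than this note shows. Statements on the series, on what has been measured and on what is new or still open speak of the compounds shown alone.

Measured compounds:
compound 1 `Clc1ccc(OC(CCn2ccnc2)c2ccccc2)cc1` 256000 nM
compound 2 `Clc1ccc(OC(CCn2ccnc2)c2ccccc2)c(Cl)c1` 121000 nM
compound 3 `Clc1ccc(C(CCn2ccnc2)Oc2ccccc2)cc1` 186000 nM

All three have been run in an ADME assay on K562 cells (Homo sapiens) for cytotoxicity, read by MTT assay, with a stated time of 24 h; a lower number here means that less compound is tolerated, a higher number that more compound is tolerated. Compound 2 carries the change chloro in place of hydrogen on an aromatic carbon relative to compound 1, and this gives a 2.1-fold lower number from compound 1 to compound 2 (0.33 log units; beyond the scatter). Compound 3 has the same atoms as compound 1, joined differently; the difference between the two cores is not broken down here. In this assay compound 3 and compound 1 sit within the scatter of each other, as do compound 3 and compound 2, so no order among them is claimed.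

Compound 4 `Clc1ccc(C(CCn2ccnc2)Oc2ccccc2Cl)cc1` is not yet measured. It differs from compound 3 by chloro in place of hydrogen on an aromatic carbon. This is the same kind of change as from compound 1 to compound 2, not the same: in compound 2 the entering chloro is also meta to a chloro group, whereas in compound 4 it is only ortho to a large group. The expected step from compound 3 to compound 4 in this assay is a 2.0-fold lower number from compound 3 to compound 4 (0.29 log units; within the scatter), resting on the step seen for compound 1 to compound 2, a 2.1-fold lower number from compound 1 to compound 2 (0.33 log units; beyond the scatter). Compound 4 is therefore estimated at 95000 nM, with a range of 45000 nM to 200000 nM.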

Compound 4, half-maximal cytotoxic concentration: 205000 nM
Compound 4: the middle estimate sits 2.2-fold (0.33 log units) below what was measured, and the stated range ends below it.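

In this assay, for the compounds shown here, chloro in place of hydrogen on an aromatic carbon, here ortho to a large group, gives a 1.1-fold higher number from compound 3 to compound 4 (0.04 log units; within the scatter), so on the core of compound 3 the change leaves no step that can be told from the scatter. Set beside the same change on the core of compound 1, the two steps cannot be told apart: the same change on two cores in this assay, a 2.1-fold lower number (0.33 log units; beyond the scatter) from compound 1 to compound 2 and a 1.1-fold higher number (0.04 log units; within the scatter) from compound 3 to compound 4, 2.3-fold (0.37 log units) apart, within the scatter of two such steps. Going by these compounds alone, this shows no firm sign that the core alters the step, but it does not show that the step carries over unchanged, since only two pairs are available and only the step on the core of compound 1 lies beyond the scatter.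

On these data alone, every aromatic position that changes here carries only hydrogen or chloro, so it remains open how a methoxy group, a nitrile or an amine at those carbons would read in this assay. Also open, as far as these compounds go, is whether a longer chain on either core would move the numbers at all.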